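Methoxy for isobutylamino on a diterpene-quinone scaffold

This account rests on a few compounds, and the source may have more. Where it says the series, first, only, none or still open, it means among the compounds named here.

Three members of this series have been tested in a functional assay on HeLa cells (Homo sapiens) for antiproliferative activity, read by sulforhodamine B assay, with a stated time of 72 h (a higher number here means a weaker inhibitor, a lower number a stronger inhibitor), and none gave a number. Compound 1 `C=C1CCC[C@H]2[C@](C)(CC3=C(O)C(=O)C=C(OC)C3=O)[C@@H](C)CC[C@@]12C` reaches only the limit of the assay in this assay at > 10000 nM. Compound 2 `C=C1CCC[C@H]2[C@](C)(CC3=C(O)C(=O)C(CCCCC(C)=O)=C(OC)C3=O)[C@@H](C)CC[C@]12C` likewise sits at the limit in this assay with > 10000 nM. Compound 3 `C=C1CCC[C@H]2[C@](C)(CC3=C(O)C(=O)C=C(NCC(C)C)C3=O)[C@@H](C)CC[C@]12C`, the starting point of the step followed here, also returns only a limit in this assay, namely > 10000 nM; on the numbers shown it stands nowhere distinguishable from compound 1 or compound 2, since the limit of > 10000 nM in this assay, at which 3 of the 3 values shown sit, covers every value so far.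

Compound 4 `C=C1CCC[C@H]2[C@](C)(CC3=C(O)C(=O)C=C(OC)C3=O)[C@@H](C)CC[C@]12C` has not yet been tested. It differs from compound 3 as follows: methoxy in place of isobutylamino on a double-bonded ring carbon. Going by the values given here, no measured step between two compounds is available to size this change, so the expectation rests on the three limits alone. In this assay compound 4 is expected to remain at or near the limit, an estimated step that the limit leaves unreadable from compound 3 to compound 4, with no change beyond the scatter foreseen. The estimate for compound 4 in this assay is 15000 nM, in a range from 4000 nM to 60000 nM.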

Compound 4, half-maximal inhibitory concentration: > 10000 nM
Compound 4 gave a limit, no number (the forecaster's own chance of this, stated with the estimate: 80%); the middle value lies beyond the limit too.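

No step from compound 1, compound 2 or compound 3 to compound 4 can be read in this assay: the limit of > 10000 nM in this assay, at which 4 of the 4 values shown sit.

From the compounds shown here alone, it remains open whether methoxy, isobutylamino, 4-acetylbutyl or the configuration separating compound 1 from compound 4 changes activity at all, and what any compound's actual value is.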